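The compounds below may be only part of what the source reports. "The series", "measured", "known", "first", "only" and "open" are said of these compounds alone.

Measured in an assay on isolated protein for inhibition of glutathione S-transferase Mu 2 (Homo sapiens), with a stated time of 10 min; a lower number here means a stronger inhibitor, a higher number a weaker inhibitor:
- compound 1 `O=C(CCC(=O)OCCCCCCSc1ccc([N+](=O)[O-])c2nonc12)Nc1ccccc1` gives 700 nM
- compound 2 `O=C(CCC(=O)OCCCCCCSc1ccc([N+](=O)[O-])c2nonc12)Nc1ccccc1Cl` gives 330 nM

Among the compounds with values here, compound 2 holds the lowest number of the two in this assay; the only comparison is to compound 1, and the one measured step, a 2.1-fold lower number from compound 1 to compound 2 (0.33 log units; beyond the scatter), comes from putting a chloro on an aromatic carbon where compound 1 carries hydrogen.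

Compound 3 `COc1ccccc1NC(=O)CCC(=O)OCCCCCCSc1ccc([N+](=O)[O-])c2nonc12` is the next member to be run in this assay. Relative to compound 2 the change is methoxy in place of chloro on an aromatic carbon. Within the data shown here, no measured pair shows a chloro against a methoxy at this or any other position, so the step from compound 1 to compound 2 is the only one that bears on it, and it bears only indirectly: it tells that a substituent at this carbon, in place of hydrogen, lowered the number modestly, but nothing about methoxy against chloro. The expectation is therefore a small step, from compound 2 to compound 3, of a 1.4-fold higher number from compound 2 to compound 3 (0.13 log units; within the scatter), with a number above compound 2 and below or near compound 1 judged plausible. For compound 3 the estimate in this assay is 450 nM, expected to fall between 200 nM and 1000 nM.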

Compound 3, half-maximal inhibitory concentration: 280 nM
Beside the measured number, compound 3's estimate is 1.6-fold (0.21 log units) above it, and the stated range covers the measured number.
By their numbers in this assay, from the lowest: compounds 3 and 2 (each within the scatter of the next); then compound 1.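

Exchanging chloro for methoxy on this aromatic carbon, ortho to a large group, gives in this assay a step that separates neither group from the other: a 1.2-fold lower number from compound 2 to compound 3 (0.07 log units; within the scatter). The exchange adds a heavy atom and a hydrogen-bond acceptor, yet these two compounds remain indistinguishable in this measurement, while methoxy in place of hydrogen gives a 2.5-fold lower number from compound 1 to compound 3 (0.40 log units; beyond the scatter), so the lower number against compound 1 now holds for two different substituents at this carbon rather than for chloro alone. No supporting measurement is available to account for this result.

On these data alone, whether the lower number against compound 1 extends to other groups at this carbon remains open, as an amine, a carboxylic acid or a simple methyl could either continue or break the match between chloro and methoxy. Also open, as far as these compounds go, are the same substituents on the other carbons of this aromatic ring, and whether a longer chain in the linker would change the size of the steps seen here in this assay.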